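Aryl substituent swap on the shared core: methoxy to trifluoromethyl

The source may report more compounds than this note shows. Statements on the series, on what has been measured and on what is new or still open speak of the compounds shown alone.

Compound 3 `COc1cncc(C2=CC3CNCC(C2)C3)c1` is the second highest of three numbers in an in vitro assay on SH-SY5Y cells for displacement of a labelled ligand from Neuronal acetylcholine receptor; alpha3/beta4 (Homo sapiens) (a higher number here means a weaker inhibitor, a lower number a stronger inhibitor), where compound 3 gives 14.3 nM. Compound 1 `CC(C)Oc1cncc(C2=CC3CNCC(C2)C3)c1` has the lowest number in this assay, as compound 1 gives 4.8 nM, while compound 2 `Clc1cncc(C2=CC3CNCC(C2)C3)c1` has the highest, as compound 2 gives 40 nM. Two steps frame compound 3: a 3.0-fold higher number from compound 1 to compound 3 (0.47 log units; beyond the scatter), and a 2.8-fold lower number from compound 2 to compound 3 (0.45 log units; beyond the scatter); the remaining step, an 8.3-fold higher number from compound 1 to compound 2 (0.92 log units; beyond the scatter), is the largest in the set.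

Compound 4 `FC(F)(F)c1cncc(C2=CC3CNCC(C2)C3)c1` differs from compound 3 by trifluoromethyl in place of methoxy on an aromatic carbon. The step that bears most directly on this change is a 2.8-fold lower number from compound 2 to compound 3 (0.45 log units; beyond the scatter), read in reverse: taking the methoxy out of compound 3 in favour of a group without a hydrogen-bond acceptor is the same kind of exchange that separated compound 2 from compound 3, and a number of the order of compound 2 is therefore expected for compound 4, in the direction of weaker binding. A step of about a 2.8-fold higher number from compound 3 to compound 4 (0.45 log units; beyond the scatter) is expected, beyond the scatter but modest. For the measured compounds named here, compound 4 is expected to give roughly 40 nM in this assay, within a range of 15 nM to 120 nM; no measured step shows a trifluoromethyl, so the range is kept wide.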

Compound 4, inhibition constant: 79 nM
Estimate against measurement, compound 4: 2.0-fold (0.30 log units) below; the range from low to high includes it.
By their numbers in this assay, from the lowest: compound 1; then compound 3; then compounds 2 and 4 (each within the scatter of the next).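

In this assay, for the compounds shown here, the change gives a 5.5-fold higher number from compound 3 to compound 4 (0.74 log units; beyond the scatter) and the wider exchange gives a 16-fold higher number from compound 1 to compound 4 (1.22 log units; beyond the scatter) as the largest step in the set, so this position on the six-membered aromatic ring with 1 nitrogen spans more than the earlier compounds showed. With a 2.0-fold higher number from compound 2 to compound 4 (0.30 log units; within the scatter) as the remaining new step, chloro and trifluoromethyl cannot be told apart here, despite their different groups, so a second oxygen-free group now sits with compound 2, well away from compound 1 and compound 3. Among these four compounds, the two with an oxygen on the aromatic carbon give the lower numbers and none of the four goes against that pattern, though no measurement available here explains it.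

The compounds shown leave open whether the oxygen itself or the alkyl group on it matters more, as only methoxy and isopropoxy represent the oxygen-linked groups. An amine or a methyl group at this position would test whether the lower numbers need an oxygen, and a longer alkoxy chain such as butoxy would show whether the gain from methoxy to isopropoxy continues.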